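Two Selenium Nucleosides and an Inverted Ring Stereocentre

The source may report more compounds than this note shows. Statements on the series, on what has been measured and on what is new or still open speak of the compounds shown alone.

Measured compounds:
compound 1, `Nc1nc(O)c2ncn([C@H]3C[Se][C@@H](CO)O3)c2n1`: > 100000 nM
compound 2, `O=c1ccn([C@@H]2C[Se][C@@H](CO)O2)c(=O)[nH]1`: > 100000 nM

In a functional assay on CCRF-CEM cells (Homo sapiens) for cytotoxicity (a higher number here means a weaker inhibitor, a lower number a stronger inhibitor), compound 1 gives > 100000 nM, which is a limit of the assay and not a number. In this assay compound 2 likewise gives > 100000 nM, also a limit. Both values therefore rest at the limit of > 100000 nM in this assay, at which 2 of the 2 values shown sit, so no step between measured compounds can be read, and nothing places compound 1 above or below any other compound on the numbers shown.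

Compound 3 `Nc1nc(O)c2ncn([C@@H]3C[Se][C@@H](CO)O3)c2n1` has not yet been measured in this assay. It differs from compound 1 in this way: the two compounds have the same atoms and bonds and differ only in configuration as drawn: 1 of 2 stereo elements differ; a stereocentre at a saturated ring carbon is drawn R in compound 1 and S in compound 3. Among the compounds with values here, no measured pair here shows the effect of such a change, so the size of the step in this assay cannot be taken from the data. Because compound 1 sits at the limit of > 100000 nM in this assay, at which 2 of the 2 values shown sit, the expectation is that compound 3 will also most likely be reported as a limit rather than a number. For compound 3 the estimated value in this assay is 100000 nM, with a range from 30000 nM to 300000 nM. This estimate means an expected step of a number no higher from compound 1 to compound 3 (the limit leaves the size open), none beyond the scatter.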

Compound 3, half-maximal inhibitory concentration: > 100000 nM
Compound 3 gave a limit, no number (the forecaster's own chance of this, stated with the estimate: 85%); the middle value sits exactly at the limit.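

In this assay compound 3 gives > 100000 nM as a limit and not a number. No step can be read between compound 1 and compound 3, whose values both rest at that limit: the limit of > 100000 nM in this assay, at which 3 of the 3 values shown sit. The compounds shown leave open whether the configuration at this saturated ring carbon affects cytotoxicity at all.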